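Swapping the aryl substituent on a hydrazone core

A few compounds are considered here, and "the series" means these few. Any claim that something is new, unique, unknown or untested is made for them only; others in the source may bear on it.

Measured compounds:
compound 1 `CC1CC/C(=N\Nc2ccc(F)cc2)c2ncc(C(=O)O)c(=O)n21` with 1200 nM
compound 2 `Cc1cccc(N/N=C2\CCC(C)n3c2ncc(C(=O)O)c3=O)c1` with 72900 nM

In a functional assay (mast cells) for inhibition, with Rattus norvegicus as the target (on this read-out lower numbers stand for an effect already at smaller amounts and higher numbers for an effect only at larger amounts of compound), compound 1 gives 1200 nM, the lowest of the two numbers measured. Compound 2 `Cc1cccc(N/N=C2\CCC(C)n3c2ncc(C(=O)O)c3=O)c1` differs from it only in the aryl group on the amine nitrogen, and there the step of a 61-fold higher number from compound 1 to compound 2 (1.78 log units; beyond the scatter) shows that this part of the molecule matters a great deal. Compound 3 `CNC(=O)c1ccc(N/N=C2\CCC(C)n3c2ncc(C(=O)O)c3=O)cc1` keeps the core of compound 1 and changes that same aryl group: methylcarbamoyl in place of fluoro on an aromatic carbon. Among the compounds with values here, no measured step covers this exact change, so the only guide is that the one alteration tried here at this position cost a lot in this assay. The new group is larger than fluoro and brings a hydrogen-bond donor and acceptor, and an effect in either direction is plausible; a step of a 2.9-fold higher number from compound 1 to compound 3 (0.46 log units; beyond the scatter) is expected, with wide uncertainty. Compound 3 is therefore estimated at 3500 nM, within 500 nM to 25000 nM.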

Compound 3, half-maximal effective concentration: 100000 nM
For compound 3 the middle estimate is 29-fold (1.46 log units) below the measured one; the whole stated range lies below it.
By their numbers in this assay, from the lowest: compound 1; then compounds 2 and 3 (each within the scatter of the next).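

In this assay, putting methylcarbamoyl in place of fluoro gives an 83-fold higher number from compound 1 to compound 3 (1.92 log units; beyond the scatter) and so shows that a second, quite different change to this aryl group also pushes the number far up. Compound 2 had shown this only for 3-methylphenyl in place of 4-fluorophenyl, whereas compound 3 keeps a substituent on the same ring carbon and changes only the group there, so this one spot on the ring is sensitive to what it carries. No measurement at hand gives a reason for this rise.

From the compounds shown here alone, whether a chloro, methyl or methoxy group in place of fluoro would keep the number close to that of compound 1 stays open. Going by these compounds, it is also open whether a nitrile or an amine at this spot would behave like methylcarbamoyl.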